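Fluorobenzyl limits and a hydroxy-methyl benzyl change

The source may hold more compounds than are shown below. What is called first, only, known or untested is meant among the compounds shown, and "the series" means these compounds.

In a functional assay on G-361 cells (Homo sapiens) for antiproliferative activity, with a stated time of 72 h (on this read-out higher numbers stand for weaker inhibition and lower numbers for stronger inhibition), compound 1 (`OC[C@H]1O[C@@H](n2cnc3c(NCc4ccc(F)cc4)ncnc32)[C@H](O)[C@@H]1O`) gives > 166000 nM as a limit and not a number. Compound 2 (`OC[C@H]1O[C@@H](n2cnc3c(NCc4ccc(F)cc4F)ncnc32)[C@H](O)[C@@H]1O`) gives > 166000 nM as a limit too. Both values stand on the limit of > 166000 nM in this assay, at which 2 of the 2 values shown sit, and compound 2 therefore has no number of its own.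

The move to compound 3 (`Cc1cccc(CNc2ncnc3c2ncn3[C@@H]2O[C@H](CO)[C@@H](O)[C@H]2O)c1O`) is 2-hydroxy-3-methylphenyl in place of 2,4-difluorophenyl on a saturated chain carbon bound to a nitrogen on an aromatic ring and it replaces the whole 2,4-difluorobenzyl with 2-hydroxy-3-methylbenzyl. For the measured compounds named here, the only measured step that bears on it is a step that the two limits leave unreadable from compound 1 to compound 2 and its size cannot be read, so no measured size carries over to this change.

The limit of compound 2 at > 166000 nM leaves room only toward stronger inhibition, so any readable step is expected in that direction. The expected step is an at least 4.1-fold lower number from compound 2 to compound 3 (0.61 log units; beyond the scatter) as an estimate with little measured support. Compound 3 is estimated at 40000 nM with an expected range from 5000 nM to 166000 nM and a real chance of another limit.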

Compound 3, half-maximal inhibitory concentration: > 166000 nM
Compound 3 ended at the assay's limit (the forecaster's own chance of this, stated with the estimate: 45%); middle value at least 4.1-fold (0.61 log units) away from the limit.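

In this assay compound 3 gives > 166000 nM, a limit and not a number. The steps among compound 1, compound 2 and compound 3 therefore cannot be read, as all three rest on the same limit: the limit of > 166000 nM in this assay, at which 3 of the 3 values shown sit.

The compounds shown leave open whether any benzyl group on the shared core gives a measurable value in this assay.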